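This account rests on a few compounds, and the source may have more. Where it says the series, first, only, none or still open, it means among the compounds named here.

Measured compounds in a functional assay on the whole organism for antagonist activity, with Mus musculus as the target; on this read-out lower numbers stand for an effect already at smaller amounts and higher numbers for an effect only at larger amounts of compound:

- compound 1, `CC1CCC(=O)N1CC#CCn1ccnc1`: compound 1 gives 0.54 mg/kg
- compound 2, `CC1CCC(=O)N1CC#CCN(C)C`: compound 2 gives only a limit of the assay, > 100 mg/kg
- compound 3, `COC(=O)N(C)CC#CCn1ccnc1`: compound 3 gives only a limit of the assay, > 100 mg/kg

Going by the values given here, the one measured step is from compound 1 to compound 2, the change (dimethylamino in place of 1H-imidazol-1-yl on a saturated chain carbon bound to a triple-bonded carbon). It made an at least 180-fold higher number from compound 1 to compound 2 (2.26 log units; beyond the scatter). Its true size is open-ended, since compound 2 sits at the limit of > 100 mg/kg in this assay, at which 2 of the 3 values shown sit, and only a lower bound of the step is known.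

Compound 3 carries a different core; the difference between the core of compound 1 and the core of compound 3 is not broken down here. Compound 3 is itself read only as a limit in this assay.

Compound 4, `COC(=O)N(C)CC#CCN(C)C`, is not yet measured. It differs from compound 3 by dimethylamino in place of 1H-imidazol-1-yl on a saturated chain carbon bound to a triple-bonded carbon, the same change, at the same place, as from compound 1 to compound 2. Among the compounds with values here, in the one case where this change was measured it moved the value past the limit of the assay, and compound 3 already stands at that limit with > 100 mg/kg. Within the data shown here, nothing among the measured compounds suggests the change would bring the number down. The step from compound 3 to compound 4 is therefore expected to be about a step that the limit leaves unreadable from compound 3 to compound 4, resting on the step from compound 1 to compound 2 and on the limit reading of compound 3. Compound 4 is expected at 300 mg/kg, somewhere between 100 mg/kg and 3000 mg/kg, and is most likely to be reported as a limit only.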

Compound 4, dose for half-maximal effect: > 30 mg/kg
Compound 4: no number, only a limit; the forecaster's own chance of this, stated with the estimate: 95%; the middle value does not contradict the limit.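

In this assay compound 3 gives only a limit, > 100 mg/kg. Compound 4 also gives only a limit, > 30 mg/kg. With two limits, no step can be read between compound 3 and compound 4. The compounds shown leave open whether dimethylamino in place of 1H-imidazol-1-yl changes the read-out at all on the core of compound 3.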